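The source may report more compounds than this note shows. Statements on the series, on what has been measured and on what is new or still open speak of the compounds shown alone.

Compound 1 `COc1cc(N)c(Cl)cc1NC(=O)C1CCN(C2CCCC2)CC1`: > 10 mg/kg
Compound 2 `COc1cccc(CN2CCC(C(=O)Nc3cc(Cl)c(N)cc3OC)CC2)c1`: > 4 mg/kg

In a functional assay on the whole organism for antagonist activity, with Mus musculus as the target (a lower number here means that less compound is needed, a higher number that more compound is needed for the effect), compound 1 gives > 10 mg/kg, which is a limit of the assay and not a number. Compound 2 gives > 4 mg/kg, also only a limit. Compound 2 therefore stands only as a limit, and the step that the two limits leave unreadable from compound 1 to compound 2 cannot be read, as the limit of > 10 mg/kg in this assay, at which 1 of the 2 values shown sits, and the limit of > 4 mg/kg in this assay, at which 1 of the 2 values shown sits, show. Compound 3 `COc1cc(N)c(Cl)cc1NC(=O)C1CCN(Cc2ccccc2)CC1` differs from compound 2 by hydrogen in place of methoxy on an aromatic carbon, turning 3-methoxybenzyl into benzyl. No readable measured step bears on this change, so the expected step that the limit leaves unreadable from compound 2 to compound 3 is none beyond the scatter. Compound 3 is estimated at 6 mg/kg in this assay, ranging from 2 mg/kg to 20 mg/kg.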

Compound 3, dose for half-maximal effect: 0.5 mg/kg
Estimate against measurement, compound 3: 12-fold (1.08 log units) above; measured number below the stated range.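

In this assay, within the data shown here, compound 3 is the first compound here with a measured number rather than a limit, and the step between compound 1 and compound 2 cannot be read. Hydrogen in place of methoxy on the aromatic carbon gives an at least 8.0-fold lower number from compound 2 to compound 3 (0.90 log units; beyond the scatter), so the outcome is sensitive to this one change. Benzyl in place of cyclopentyl on the ring nitrogen gives an at least 20-fold lower number from compound 1 to compound 3 (1.30 log units; beyond the scatter). Still open, from the compounds shown here alone, is how fluorine or methyl on that aromatic carbon would compare. Also open, going by these compounds, is whether a longer chain between the ring nitrogen and the phenyl would keep the low number.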